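This account rests on a few compounds, and the source may have more. Where it says the series, first, only, none or still open, it means among the compounds named here.

For the measured compounds named here, in a functional assay on HCT-116 cells (Homo sapiens) for antiproliferative activity, read by MTT assay, with a stated time of 72 h (a higher number here means a weaker inhibitor, a lower number a stronger inhibitor), compound 1 `NC1=NC2(CCSCC2)N(OCCCOc2ccc(Cl)c(Cl)c2)C(N)=N1` gives 1 nM and holds the lower of the two numbers so far, against compound 2 `NC1=NC2(CCOCC2)N(OCCCOc2cccc(Cl)c2Cl)C(N)=N1` at 5 nM in the same read-out. Compound 3 `NC1=NC2(CCSCC2)N(OCCCOc2cccc(Cl)c2Cl)C(N)=N1` keeps the core of compound 1 and has 2,3-dichlorophenyl in place of 3,4-dichlorophenyl on an oxygen on a saturated carbon. Going by the values given here, no measured step isolates this change. Among the compounds with values here, compound 2, the only measured compound with 2,3-dichlorophenyl, stands at 5 nM and so suggests a rise. The step of a 2.5-fold higher number from compound 1 to compound 3 (0.40 log units; beyond the scatter) in this assay is therefore expected to be a modest rise in the number. Compound 3 is estimated at 2.5 nM (expected range 0.8 nM to 8 nM).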

Compound 3, half-maximal inhibitory concentration: 1 nM
Compound 3: the middle estimate sits 2.5-fold (0.40 log units) above what was measured; the measured number falls inside the stated range.
By their numbers in this assay, from the lowest: compounds 1 and 3 (each within the scatter of the next); then compound 2.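

In this assay, 2,3-dichlorophenyl in place of 3,4-dichlorophenyl gives no change at the digits printed from compound 1 to compound 3 (within the scatter), so on the core of compound 1 this position accepts either dichlorophenyl group. Compound 2 gives 5 nM and compound 3 gives 1 nM with the same 2,3-dichlorophenyl, so that group alone does not account for the higher number of compound 2. No available data bear on the reason for this result. Still open, as far as these compounds go, is whether an unsubstituted phenyl, a pyridine ring or a longer chain would keep the number in this assay.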